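The source may report more compounds than this note shows. Statements on the series, on what has been measured and on what is new or still open speak of the compounds shown alone.

In a functional assay on SF-268 cells (Homo sapiens) for cytotoxicity, read by sulforhodamine B assay, with a stated time of 48 h, tested at 100 nM (on this read-out lower numbers stand for a stronger effect and higher numbers for a weaker effect at the one concentration tested), three compounds have been measured so far. Compound 1 `COc1cc(C)cc(-c2nn(CC#N)cc2-c2ccc(-c3cccc(C(C)=O)c3)nc2)c1` gives 91%, and compound 2 `Cc1cc(O)cc(-c2nn(CC#N)cc2-c2ccnc(-c3ccc(Oc4ccccc4)cc3)c2)c1` gives 91%; these two numbers lie within the usual scatter of each other, so no order can be read between them. Compound 3 `COc1cc(C)cc(-c2nn(CC#N)cc2-c2ccnc(-c3ccc(N(C)C)cc3)c2)c1` gives 31%, the lowest of the three and thus the strongest effect seen, a number well beyond the scatter from both of the others.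

Compound 4 `Cc1cc(O)cc(-c2nn(CC#N)cc2-c2ccnc(-c3ccc(N(C)C)cc3)c2)c1` has not been measured yet. It differs from compound 3 in one place: hydrogen in place of methyl on an oxygen on an aromatic ring. Compound 2 carries the same hydroxy group as compound 4, but the rest of its structure differs as well, so its value alone cannot tell what this exchange does. Among the compounds with values here, no measured pair differs in this one place only, so the size of the step must be estimated. Compound 4 is expected to keep much of the effect of compound 3, with a step of a number 14 percentage points higher from compound 3 to compound 4 (beyond the scatter) that is modest and could run either way. The estimate for compound 4 is 45%, with a range from 20% to 80%.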

Compound 4, a percentage reported as activity, at one concentration (the size of the read-out at that concentration, not a potency): 90%
Compound 4: middle estimate off by 45 percentage points, on the low side; the measured number lies above the stated range.
By their numbers in this assay, from the lowest: compound 3; then compounds 4, 1 and 2 (each within the scatter of the next).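

In this assay, the exchange of methoxy for hydroxy on the 3-methoxy-5-methylphenyl group gives a number 59 percentage points higher from compound 3 to compound 4 (beyond the scatter), so a single methyl on this oxygen separates a clear effect from almost none. With the hydroxy group in place, dimethylamino in place of phenoxy gives a number 1 percentage points lower from compound 2 to compound 4 (within the scatter), so dimethylamino alone does not carry the effect in this pair, and the two groups cannot be told apart here. Nothing available explains why the methyl matters so much.

On these data alone, it remains open whether the methoxy group needs dimethylamino to act, which a methoxy compound carrying phenoxy would test. As far as these compounds go, it is also open whether a larger ethoxy group or an amine at this position would keep the effect.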